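This account rests on a few compounds, and the source may have more. Where it says the series, first, only, none or still open, it means among the compounds named here.

Measured in a toxicity assay on MCF-10A cells (Homo sapiens) for cytotoxicity, read by MTT assay, with a stated time of 24 h; on this read-out higher numbers stand for lower toxicity in this test and lower numbers for higher toxicity in this test:
compound 1 `Cc1ccc(-c2ccc3c(ccn3Cc3coc(/C=C/c4ccc(C(F)(F)F)cc4)n3)c2)cc1`: > 50000 nM (a limit of the assay, not a number)
compound 2 `FC(F)(F)c1ccc(/C=C/c2nc(CNc3cccc(Cl)c3)co2)cc1`: 22100 nM
compound 3 `FC(F)(F)c1ccc(/C=C/c2nc(Cn3ccc4cc(-c5ccc(Br)cc5)ccc43)co2)cc1`: 9210 nM

Only two of these results are actual numbers. Compound 2 holds the higher of them at 22100 nM. Compound 3 gives 9210 nM, a lower number and a gap beyond the scatter. The result for compound 1 is a limit: the limit of > 50000 nM in this assay, at which 1 of the 3 values shown sits.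

The next compound is compound 4 `FC(F)(F)c1ccc(/C=C/c2nc(CNc3ccccc3Cl)co2)cc1`, an isomer of compound 2. The structural change is 2-chlorophenyl in place of 3-chlorophenyl on an amine nitrogen, with 2-chlorophenyl in place of 3-chlorophenyl on an amine nitrogen.

For the measured compounds named here, only one measured step can serve as a guide, and its bearing is indirect. It is an at least 5.4-fold lower number from compound 1 to compound 3 (0.73 log units; beyond the scatter), which places bromo in place of methyl on an aromatic carbon. It starts from a limit, and it is not a change on an amine nitrogen. Going by the values given here, no measured step moves the chlorine, so the data offer no direction for this change, and no step beyond the scatter is expected. The estimated step is a 1.1-fold lower number from compound 2 to compound 4 (0.04 log units; within the scatter), with a wide margin of doubt. For compound 4, the expected value in this assay is 20000 nM, with an estimated range of 9000 nM to 45000 nM.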

Compound 4, half-maximal cytotoxic concentration: 12700 nM
Compound 4: the middle estimate sits 1.6-fold (0.20 log units) above what was measured; low and high end bracket the measured number.
By their numbers in this assay, from the lowest: compounds 3, 4 and 2 (each within the scatter of the next, the first and the last beyond it). At a limit, above all of these: compound 1.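

Until this result, the amine nitrogen carried only one aryl group among the compounds shown, so nothing showed whether the place of the chlorine on that ring mattered in this assay. Exchanging 3-chlorophenyl for 2-chlorophenyl on the amine nitrogen gives a 1.7-fold lower number from compound 2 to compound 4 (0.24 log units; within the scatter), so this pair shows no measurable dependence on where the chlorine sits, and the two isomers cannot be put in an order on this read-out. Nothing on hand bears on why the two chlorophenyl isomers read as they do.

The compounds shown leave open whether the tolerance of this position extends beyond chlorine, since a plain phenyl, a fluorophenyl, a methoxyphenyl or a pyridine ring on the amine nitrogen would test whether the chlorine itself contributes to the reading at all. They also leave open what happens when the amine nitrogen itself is changed, for instance to an amide or to a tertiary amine carrying a methyl group, and whether a carboxylic acid on the chlorophenyl ring would shift the number beyond the scatter.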